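Pyrimidinyl in place of pyridinyl: expected cytotoxicity

The source may hold more compounds than are shown below. What is called first, only, known or untested is meant among the compounds shown, and "the series" means these compounds.

This account concerns three measured vinyl sulfones and a fourth that has not yet been tested. Compound 1 `COc1ccc(S(=O)(=O)/C=C/c2ccccn2)cc1` gives 100% in an ADME assay on BV-2 cells (Mus musculus) for cytotoxicity, with a stated time of 24 h, tested at 50 uM; a higher number here means a weaker effect of the compound at the concentration tested, a lower number a stronger effect. Compound 2 `COc1ccc(S(=O)(=O)/C=C/c2cccnc2)cc1` gives 85.8% in this assay, and compound 3 `COc1ccc(S(=O)(=O)/C=C/c2ccncc2)cc1` gives 69%. Compound 3 stands lowest of the three numbers: the step of a number 16.8 percentage points lower from compound 2 to compound 3 (beyond the scatter) and the step of a number 31 percentage points lower from compound 1 to compound 3 (beyond the scatter) both lie beyond the scatter, so compound 3 shows the strongest effect among them.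

Compound 4 `COc1ccc(S(=O)(=O)/C=C/c2cncnc2)cc1` differs from compound 3 in one place: pyrimidin-5-yl in place of pyridin-4-yl on a double-bonded chain carbon bound to a double-bonded chain carbon. Among the compounds with values here, none of the measured steps exchanges pyridin-4-yl for pyrimidin-5-yl; they only move among the three pyridinyl groups. The step of a number 14.2 percentage points lower from compound 1 to compound 2 (beyond the scatter) was modest. The two steps that end at compound 3 were larger. These steps give no direct guide to a second ring nitrogen, so the size and direction of the change are uncertain. The expected step is a number 3 percentage points higher from compound 3 to compound 4 (within the scatter), which stays within the scatter. Compound 4 is therefore estimated at 72%, with a range from 52% to 92%.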

Compound 4, a percentage reported as activity, at one concentration (the size of the read-out at that concentration, not a potency): 100%
Estimate against measurement, compound 4: 28 percentage points below; measured number outside the range, above it.
By their numbers in this assay, from the lowest: compound 3; then compound 2; then compounds 1 and 4 (each within the scatter of the next).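

The exchange of pyridin-4-yl for pyrimidin-5-yl, on a double-bonded chain carbon bound to a double-bonded chain carbon, is not a small adjustment: a number 31 percentage points higher from compound 3 to compound 4 (beyond the scatter) is as large as any step among the pyridinyl compounds, and a number 14.2 percentage points higher from compound 2 to compound 4 (beyond the scatter) shows that compound 4 also parts from the pyridin-3-yl compound in the direction of a weaker effect in this assay. With no change at the digits printed from compound 1 to compound 4 (within the scatter), compound 4 cannot be told apart from the pyridin-2-yl compound, so a ring with 2 hetero atoms at this place gives the same reading as one of the rings with 1 hetero atom, and the count of ring nitrogens does not by itself order these four compounds. The data shown offer no measurement that explains this result.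

The compounds shown leave open whether other rings at this place, such as pyrimidin-2-yl, pyrazin-2-yl or a plain phenyl, would read like compound 3 or like compound 4. They also leave open whether an amine or a methyl group on the pyrimidin-5-yl ring would keep the reading of compound 4, and how any of these compounds would behave at concentrations other than the single one tested.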